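Compound 2 to compound 3: a step among limits

A few compounds are considered here, and "the series" means these few. Any claim that something is new, unique, unknown or untested is made for them only; others in the source may bear on it.

In a functional assay on 786-0 cells (Homo sapiens) for inhibition, read by sulforhodamine B assay, with a stated time of 48 h (on this read-out higher numbers stand for weaker inhibition of growth and lower numbers for stronger inhibition of growth), compound 1 `CCOC(=O)c1nn(-c2ccc(Cl)cc2)c(-c2ccc(F)cc2)c1CNC(C)(C)C` carries the 4-chlorophenyl group and gives > 582000 nM; > 537000 nM (2 entries) in two entries, each a limit. Compound 2 `CC(C)(C)NCc1c(C(=O)O)nn(-c2ccccc2)c1-c1ccc(F)cc1` gives > 680000 nM as a limit, so it stands without a single number. Compound 3 `CC(C)(C)NCc1c(C(=O)O)nn(-c2ccc(Cl)cc2)c1-c1ccc(F)cc1` differs from compound 2 by chloro in place of hydrogen on an aromatic carbon in the form of phenyl to 4-chlorophenyl, chloro in place of hydrogen on an aromatic carbon. Going by the values given here, no measured step covers this change, so no shift beyond the usual scatter is expected in either direction in this assay and another limit is likely. The estimated size is an at least 1.1-fold lower number from compound 2 to compound 3 (0.05 log units; that floor lies within the scatter) within that expectation. Compound 3 is estimated at 600000 nM with an expected range from 200000 nM to 800000 nM if a number is reported at all.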

Compound 3, concentration for 50% growth inhibition: 204000 nM
Beside the measured number, compound 3's estimate is 2.9-fold (0.47 log units) above it; the range from low to high includes it.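

In this assay, phenyl to 4-chlorophenyl gives an at least 3.3-fold lower number from compound 2 to compound 3 (0.52 log units; beyond the scatter), the first step read at this position, where chloro replaces hydrogen para to a large group. The step is a floor, and compound 3 is the only compound shown with a single number. The 4-chlorophenyl group alone does not bring a single number, since compound 1 carries it and stays a limit in both entries: the several entries of compound 1 in this assay, > 582000 nM; > 537000 nM (2 entries)

The compounds shown leave open whether bromo or methoxy at this position gives a like step. As far as these compounds go, whether the step holds with an amide in place of the carboxylic acid also remains open.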